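The source may hold more compounds than are shown below. What is called first, only, known or untested is meant among the compounds shown, and "the series" means these compounds.

Compounds measured so far:
Compound 1, `CNC(=O)C1=CC(C)(CF)Oc2ccc([N+](=O)[O-])cc21`: 8.91 nM
Compound 2, `CNC(=O)C1=CC(CF)(CF)Oc2ccc([N+](=O)[O-])cc21`: 5.13 nM
Compound 3, `CC1(C)C=C(/C(S)=N\CCC#N)c2cc([N+](=O)[O-])ccc2O1`: 0.372 nM

All three were tested in a functional assay (aorta) with Rattus norvegicus as the target; on this read-out higher numbers stand for an effect only at larger amounts of compound and lower numbers for an effect already at smaller amounts. Compound 1 and compound 2 share one core, and the difference between them is fluoro in place of hydrogen on a saturated chain carbon bound to a saturated ring carbon. That step gave a 1.7-fold lower number from compound 1 to compound 2 (0.24 log units; within the scatter). Compound 3 carries a different core; the difference between the two cores is not broken down here. In this assay compound 3 sits at the lowest of the three numbers, and its gap to compound 2 and to compound 1 lies beyond the scatter in each case.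

Compound 4, `CC1(CF)C=C(/C(S)=N\CCC#N)c2cc([N+](=O)[O-])ccc2O1`, has not yet been measured. It differs from compound 3 by fluoro in place of hydrogen on a saturated chain carbon bound to a saturated ring carbon, the same change as from compound 1 to compound 2, made at the same kind of place. Because the earlier step was a 1.7-fold lower number from compound 1 to compound 2 (0.24 log units; within the scatter), compound 4 is expected to move by about a 1.5-fold lower number from compound 3 to compound 4 (0.17 log units; within the scatter), a shift that would itself stay within the scatter. Compound 4 is therefore estimated at 0.25 nM in this assay, between 0.1 nM and 0.7 nM.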

Compound 4, half-maximal effective concentration: 1.86 nM
Estimate against measurement, compound 4: 7.4-fold (0.87 log units) below, and the stated range ends below it.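

In this assay the change from methyl to fluoromethyl did not carry over from one core to the other: the same change on two cores in this assay, a 1.7-fold lower number (0.24 log units; within the scatter) from compound 1 to compound 2 and a 5.0-fold higher number (0.70 log units; beyond the scatter) from compound 3 to compound 4, 8.7-fold (0.94 log units) apart, beyond the scatter of two such steps. On the core of compound 3 the change gave a 5.0-fold higher number from compound 3 to compound 4 (0.70 log units; beyond the scatter), so the near-flat step on the other core was a poor guide here, while swapping the group of 4 heavy atoms for the group of 7 heavy atoms on a double-bonded ring carbon, with the fluoromethyl group kept, gave a 4.8-fold lower number from compound 1 to compound 4 (0.68 log units; beyond the scatter). This shows that the effect of the change depends on the core in these compounds, but it rests on a single pair per core and does not show why the two cores differ or whether the same would hold for other cores.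

From the compounds shown here alone, it remains open whether a chloromethyl, difluoromethyl or trifluoromethyl group in that place would follow the same course on each core. Also open, going by these compounds, is how a second fluoromethyl group, as carried by compound 2, would act on the core of compound 3.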